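Working notes: one stereocentre changed from compound 2

The source may report more compounds than this note shows. Statements on the series, on what has been measured and on what is new or still open speak of the compounds shown alone.

Measured in a functional assay on OVCAR-8 cells (Homo sapiens) for inhibition, read by sulforhodamine B assay, with a stated time of 48 h; on this read-out lower numbers stand for stronger inhibition of growth and higher numbers for weaker inhibition of growth
- compound 1 `Cc1cn([C@H]2C[C@H](CC3=CC(=O)C(=O)C=C3)[C@@H](CO[Si](C)(C)C(C)(C)C)O2)c(=O)[nH]c1=O`: no result reported
- compound 2 `COc1ccc(C2([C@H]3C[C@H](n4cc(C)c(=O)[nH]c4=O)O[C@@H]3CO[Si](C)(C)C(C)(C)C)SCCCS2)cc1OC`: 3890 nM

For the measured compounds named here, compound 2 holds the only number in this assay, at 3890 nM, so it cannot yet be ranked against anything. Going by the values given here, compound 1 offers no comparison, and no pair of measured compounds gives a step. The data therefore do not show how this read-out responds to a change in configuration.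

The next compound is compound 3 `COc1ccc(C2([C@H]3C[C@@H](n4cc(C)c(=O)[nH]c4=O)O[C@@H]3CO[Si](C)(C)C(C)(C)C)SCCCS2)cc1OC`. Its relation to compound 2 is the two compounds have the same atoms and bonds and differ only in configuration as drawn: 1 of 3 stereo elements differ; a stereocentre at a saturated ring carbon is drawn R in compound 2 and S in compound 3. Nothing leaves and nothing enters: a stereocentre at a saturated ring carbon is drawn R in compound 2 and S in compound 3.

Among the compounds with values here, with no measured precedent, a modest step toward weaker inhibition of growth is expected in this assay, and a result within the scatter of compound 2 would not be surprising. The expected change is a 1.2-fold higher number from compound 2 to compound 3 (0.06 log units; within the scatter). The estimated value for compound 3 is 4500 nM, with an expected range from 1800 nM to 12000 nM.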

Compound 3, concentration for 50% growth inhibition: 8320 nM
For compound 3 the middle estimate is 1.8-fold (0.27 log units) below the measured one, within the range that was stated.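

In this assay, for the compounds shown here, changing the stereocentre at a saturated ring carbon from R to S gives a 2.1-fold higher number from compound 2 to compound 3 (0.33 log units; beyond the scatter), the first readable step and a modest one toward weaker inhibition of growth. This position therefore responds to configuration in this read-out, although a single pair gives only one direction and one size, and the step lies only slightly beyond the usual scatter. The step can be assigned to the drawn configuration at this carbon because nothing else separates the pair: the fact that compounds 2 and 3 differ only in the configuration as drawn.

The compounds shown leave open whether the same change at this carbon would give a step of similar direction and size on a core carrying a free hydroxyl group in place of the silyl ether. They also leave open how the remaining stereo elements affect this read-out, since only one of them differs within the measured pair.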